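Side-chain amine variation: working notes on compounds 1 to 4

A few compounds are considered here, and "the series" means these few. Any claim that something is new, unique, unknown or untested is made for them only; others in the source may bear on it.

Measured in a functional assay on PC-3 cells (Homo sapiens) for cytotoxicity, read by MTT assay, with a stated time of 48 h; a lower number here means a stronger inhibitor, a higher number a weaker inhibitor:
- compound 1, `CCN(CC)CC(=O)N1N=C(C)CC1c1ccccc1OC(C)=O`: 51200 nM
- compound 2, `CC(=O)Oc1ccccc1C1CC(C)=NN1C(=O)CN1CCCCC1`: 4070 nM
- compound 3, `CC(=O)Oc1ccccc1C1CC(C)=NN1C(=O)CN1CCC(O)CC1`: 25600 nM

Compound 3 holds the second highest number of the three. Its nearest neighbour is compound 1, the step of a 2.0-fold lower number from compound 1 to compound 3 (0.30 log units; within the scatter) lying within the scatter; its furthest is compound 2, the step of a 6.3-fold higher number from compound 2 to compound 3 (0.80 log units; beyond the scatter) being the one clear difference at this ring position.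

Compound 4, `CC(=O)Oc1ccccc1C1CC(C)=NN1C(=O)CN1CCC(C(C)=O)CC1`, changes that same ring carbon: acetyl in place of hydroxy on a saturated ring carbon. The step that bears most directly on it is a 6.3-fold higher number from compound 2 to compound 3 (0.80 log units; beyond the scatter), since it sets a hydrogen and a hydroxy side by side at this carbon; the steps of a 13-fold lower number from compound 1 to compound 2 (1.10 log units; beyond the scatter) and a 2.0-fold lower number from compound 1 to compound 3 (0.30 log units; within the scatter) concern the amine swap as a whole. Going by the values given here, no measured pair places an acetyl here, so the direction is open. Given that the hydroxy compound 3 sits near compound 1 and the unsubstituted compound 2 sits lower, compound 4 is expected to fall between them, with an estimated step of a 2.1-fold lower number from compound 3 to compound 4 (0.33 log units; beyond the scatter). The estimate for compound 4 in this assay is 12000 nM, ranging from 3000 nM to 50000 nM.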

Compound 4, half-maximal inhibitory concentration: 6800 nM
Beside the measured number, compound 4's estimate is 1.8-fold (0.25 log units) above it; the range from low to high includes it.
By their numbers in this assay, from the lowest: compounds 2 and 4 (each within the scatter of the next); then compounds 3 and 1 (each within the scatter of the next).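

In this assay, acetyl in place of hydroxy gives a 3.8-fold lower number from compound 3 to compound 4 (0.58 log units; beyond the scatter), so the weaker result seen with hydroxy at this saturated ring carbon does not extend to every group placed there. Acetyl in place of hydrogen gives a 1.7-fold higher number from compound 2 to compound 4 (0.22 log units; within the scatter), which lies within the scatter, so this carbon accepts acetyl with no clear change from the unsubstituted piperidin-1-yl compound. The step of a 7.5-fold lower number from compound 1 to compound 4 (0.88 log units; beyond the scatter) adds a second substituted piperidine that stands clear of the diethylamino compound, while compound 3, with 4-hydroxypiperidin-1-yl, goes against that pattern by staying within the scatter of compound 1.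

Nothing available explains the difference between hydroxy and acetyl at this carbon. As far as these compounds go, whether a primary amine or a carboxylic acid at this carbon would track with hydroxy or with acetyl remains open.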